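Series notes: amide sugars, hexokinase-2 inhibition

The source may hold more compounds than are shown below. What is called first, only, known or untested is meant among the compounds shown, and "the series" means these compounds.

Measured so far:
compound 1 `O=C(N[C@H]1C(O)O[C@H](CO)[C@@H](O)[C@@H]1O)c1cccc(-c2ccccc2)c1` — 3200 nM
compound 2 `N#Cc1ccc(-c2cc(C(=O)N[C@H]3C(O)O[C@H](CO)[C@@H](O)[C@@H]3O)cc(C(F)(F)F)c2)cc1` — 790 nM
compound 3 `O=C(N[C@H]1C(O)O[C@H](CNS(=O)(=O)c2cccc(Cl)c2Cl)[C@@H](O)[C@@H]1O)c1ccc(Cl)s1` — 40 nM

In an assay for inhibition of hexokinase-2 (Homo sapiens), read by ADP-Glo, with a stated time of 45 min, in the presence of a further agent that is not named here (a higher number here means a weaker inhibitor, a lower number a stronger inhibitor), compound 1 gives 3200 nM, the highest of the three numbers; compound 2 sits below it beyond the scatter, and compound 3 gives 40 nM, far below it.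

Compound 4 `O=C(N[C@H]1C(O)O[C@H](CNS(=O)(=O)c2cnccc2Cl)[C@@H](O)[C@@H]1O)c1cccc(-c2ccccc2)c1` is not yet measured. It differs from compound 1 by a group of 11 heavy atoms (5 carbon, 2 nitrogen, 2 oxygen, 1 sulfur, 1 chlorine; one six-membered aromatic ring with 1 hetero atom) in place of one oxygen atom, on a saturated chain carbon bound to a saturated ring carbon. Among the compounds with values here, no measured pair shows this change in isolation. Still, a large downward step in this assay is expected, because compound 3 gives 40 nM. For compound 4 the expected value in this assay is 300 nM, with a range from 60 nM to 1500 nM. The step this estimate means is an 11-fold lower number from compound 1 to compound 4 (1.03 log units; beyond the scatter), expected to lie well beyond the scatter.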

Compound 4, half-maximal inhibitory concentration: 100 nM
The estimate for compound 4 lay 3.0-fold (0.48 log units) above the measured number, and the stated range covers the measured number.
By their numbers in this assay, from the lowest: compound 3; then compound 4; then compound 2; then compound 1.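

In this assay, a group of 11 heavy atoms with a six-membered aromatic ring bearing 1 hetero atom replaces the hydroxy on a saturated chain carbon bound to a saturated ring carbon, giving a 32-fold lower number from compound 1 to compound 4 (1.51 log units; beyond the scatter). Within the data shown here, this is the only single-place step, and it shows that this position accepts a large group with the rest of the structure held constant. No available data bear on the reason for this step.

On these data alone, whether the aromatic ring or the chlorine carries the step stays open. So does what a plain amine or a carboxylic acid would do at this position.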